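The source may hold more compounds than are shown below. What is called first, only, known or untested is meant among the compounds shown, and "the series" means these compounds.

Measured so far, in a functional assay on PC-3 cells (Homo sapiens) for cytotoxicity, read by sulforhodamine B assay, with a stated time of 48 h; on this read-out lower numbers stand for stronger inhibition of growth and higher numbers for weaker inhibition of growth:
- compound 1, `CC1=C(C(=O)Nc2ccc(Cl)c(Cl)c2)C(c2cccc(Oc3ccccc3)c2)NC(=S)N1`, gives 9770 nM
- compound 2, `CC1=C(C(=O)Nc2ccc(F)c(Cl)c2)C(c2ccccc2Cl)NC(=S)N1`, gives 20400 nM
- compound 3, `COc1cccc(C2NC(=S)NC(C)=C2C(=O)Nc2ccc(Cl)c(Cl)c2)c1`, gives 14500 nM

Compound 3 stands second highest of these three numbers; its nearest neighbour is compound 2 and its furthest is compound 1, yet both gaps are within the scatter, so the three cannot be ordered. For the measured compounds named here, the one single-point step known, a 1.5-fold higher number from compound 1 to compound 3 (0.17 log units; within the scatter), concerns a different part of the molecule.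

Compound 4, `COc1cccc(C2NC(=S)NC(C)=C2C(=O)Nc2ccc(F)c(Cl)c2)c1`, arises from compound 3 by one change: fluoro in place of chloro on an aromatic carbon. Going by the values given here, no measured step isolates this swap. Among the compounds with values here, compound 2 does carry the 3-chloro-4-fluorophenyl group, but it also differs from compound 3 elsewhere, so its value shows only that both amide groups sit in the same region. Since every measured gap here is within the scatter, a step no larger than the scatter is expected in this assay, in no particular direction: a 1.1-fold higher number from compound 3 to compound 4 (0.04 log units; within the scatter). Compound 4 is therefore estimated at 16000 nM, within 7000 nM to 35000 nM.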

Compound 4, concentration for 50% growth inhibition: 23400 nM
Estimate against measurement, compound 4: 1.5-fold (0.17 log units) below, within the range that was stated.
By their numbers in this assay, from the lowest: compounds 1, 3, 2 and 4 (each within the scatter of the next, the first and the last beyond it).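

In this assay, the first direct test of fluoro in place of chloro on this aromatic carbon, para to a large group, gives a 1.6-fold higher number from compound 3 to compound 4 (0.21 log units; within the scatter), so with the 3-methoxyphenyl group in place, 3,4-dichlorophenyl and 3-chloro-4-fluorophenyl cannot be told apart here. With 3-chloro-4-fluorophenyl held fixed, 3-methoxyphenyl in place of 2-chlorophenyl on a saturated ring carbon gives a 1.1-fold higher number from compound 2 to compound 4 (0.06 log units; within the scatter), so that exchange also stays inside the normal spread of repeated measurements. Nothing available offers an explanation for either result.

Only chloro and fluoro are shown on this carbon, so it remains open how a trifluoromethyl group, a nitrile or a plain hydrogen there would compare. Also open, from the compounds shown here alone, is whether the fluoro-for-chloro swap would give a similar result in the setting of compound 1.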